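Methoxy for methyl, read across two cores

A few compounds are considered here, and "the series" means these few. Any claim that something is new, unique, unknown or untested is made for them only; others in the source may bear on it.

Compound 1 `COc1ccc(-c2cc(NC(=S)NNC(=O)c3ccc(C)cc3)cs2)cc1` and compound 2 `Cc1ccc(C(=O)NNC(=S)Nc2csc(-c3ccc(C)cc3)c2)cc1` share one core; compound 3 `Cc1ccc(-c2nnc(Nc3csc(-c4ccccc4)c3)s2)cc1` and compound 4 `COc1ccc(-c2nnc(Nc3csc(-c4ccccc4)c3)s2)cc1` share another. In a functional assay on B16-F10 cells (Mus musculus) for inhibition, read by colorimetric assay and MTT assay, with a stated time of 72 h (on this read-out lower numbers stand for stronger inhibition and higher numbers for weaker inhibition), compound 2 gives 20000 nM, and compound 1 gives 7000 nM. The change between these two is methoxy in place of methyl on an aromatic carbon, and the step it made is a 2.9-fold lower number from compound 2 to compound 1 (0.46 log units; beyond the scatter). How the core of compound 3 differs from the core of compound 2 is not broken down here. In this assay compound 3 gives 4000 nM; its gap to compound 1 lies within the scatter, its gap to compound 2 beyond it, so no order between compound 3 and compound 1 can be read from these numbers.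

Compound 4 has not been measured. It differs from compound 3 by methoxy in place of methyl on an aromatic carbon. The description of the place is word for word the same as for the change from compound 2 to compound 1, so this is the same change, made on a different core. Within the data shown here, only one measured instance of it is at hand, and nothing shows whether the second core carries the same effect, so the expectation rests on a single step and is held loosely.

The step from compound 3 to compound 4 is expected to be a 2.7-fold lower number from compound 3 to compound 4 (0.43 log units; beyond the scatter), similar to the earlier one because the same change gave a 2.9-fold lower number from compound 2 to compound 1 (0.46 log units; beyond the scatter). Compound 4 is therefore estimated at 1500 nM in this assay, with a range from 500 nM to 4500 nM.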

Compound 4, half-maximal inhibitory concentration: 6000 nM
Beside the measured number, compound 4's estimate is 4.0-fold (0.60 log units) below it; the whole stated range lies below it.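

Methoxy in place of methyl does not act as a fixed increment across these two cores in this assay; the two readings differ by more than repeat measurement explains: the same change on two cores in this assay, a 2.9-fold lower number (0.46 log units; beyond the scatter) from compound 2 to compound 1 and a 1.5-fold higher number (0.18 log units; within the scatter) from compound 3 to compound 4, 4.3-fold (0.63 log units) apart, beyond the scatter of two such steps. On the core shared by compound 3 and compound 4 the step is a 1.5-fold higher number from compound 3 to compound 4 (0.18 log units; within the scatter), so these two compounds cannot be ordered, and the clear lowering seen on the core shared by compound 1 and compound 2 does not reappear there. This shows that the effect of the change depends on the core it sits on, but with one matched pair per core it does not show which feature of the core is responsible, nor whether the change would be neutral or favourable on any further core.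

Going by these compounds, whether the 4-methylphenyl to 4-methoxyphenyl result is specific to these two groups remains open, as does whether a chlorine, a hydroxyl, an amine or a longer chain such as ethoxy at the same place would also track the core. A matched pair on a third core would show whether the behaviour of compound 1 and compound 2 or that of compound 3 and compound 4 is the more typical for this series.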